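Oxime ether benzylation on a polyprenyl purinium scaffold

The compounds below may be only part of what the source reports. "The series", "measured", "known", "first", "only" and "open" are said of these compounds alone.

Measured compounds:
compound 1 `CC(C)=CCC/C(C)=C/CC/C(C)=C/CC/C(C)=C/C[n+]1cn(C)c2nc[nH]/c(=N\OCc3ccccc3)c21` 20900 nM
compound 2 `CO/N=c1\[nH]cnc2c1[n+](C/C=C(\C)CC/C=C(\C)CC/C=C(\C)CCC=C(C)C)cn2Cc1ccccc1` 3400 nM
compound 3 `CO/N=c1\[nH]cnc2c1[n+](C/C=C(\C)CC/C=C(\C)CC/C=C(\C)CCC=C(C)C)cn2C(c1ccccc1)c1ccccc1` 4750 nM

In a functional assay on ACHN cells (Homo sapiens) for cytotoxicity (a lower number here means a stronger inhibitor, a higher number a weaker inhibitor), compound 3 stands second highest of the three, close to compound 2 and well apart from compound 1. Among the compounds with values here, the one step that is known, a 1.4-fold higher number from compound 2 to compound 3 (0.15 log units; within the scatter), concerns the group on the ring nitrogen and stays within the scatter. Within the data shown here, compound 4 `CC(C)=CCC/C(C)=C/CC/C(C)=C/CC/C(C)=C/C[n+]1cn(C(c2ccccc2)c2ccccc2)c2nc[nH]/c(=N\OCc3ccccc3)c21` differs from compound 3 by phenyl in place of hydrogen on a saturated chain carbon bound to an oxygen, a change at the oxime ether that no measured step covers. Compound 1 also carries a benzyloxy group and gives the highest number, but it differs from compound 2 in two places at once, so its gap to compound 2 cannot be assigned to the oxime ether alone. Among the measured compounds shown here, with no direct precedent, compound 4 is expected to lie near compound 3, with at most a modest shift toward a higher number, a step of a 1.4-fold higher number from compound 3 to compound 4 (0.14 log units; within the scatter). For compound 4 the estimate in this assay is 6500 nM, within a range from 2500 nM to 17000 nM.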

Compound 4, half-maximal inhibitory concentration: 17200 nM
The estimate for compound 4 lay 2.6-fold (0.42 log units) below the measured number; the measured number lies above the stated range.
By their numbers in this assay, from the lowest: compounds 2 and 3 (each within the scatter of the next); then compounds 4 and 1 (each within the scatter of the next).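

In this assay, going from methoxy to benzyloxy at the oxime ether gives a 3.6-fold higher number from compound 3 to compound 4 (0.56 log units; beyond the scatter) and so moves the number by more than the usual scatter, which shows that this position responds to the added phenyl. Within the data shown here, the only earlier step, a 1.4-fold higher number from compound 2 to compound 3 (0.15 log units; within the scatter), placed a phenyl on a saturated chain carbon bound to an aromatic carbon and an aromatic nitrogen and stayed within the scatter, so in these two pairs the same added group reads differently at the two places. No measurement available here explains this difference.

From the compounds shown here alone, only methoxy and benzyloxy appear at this oxygen, so it remains open how an ethyl group or a chain ending in an amine would read there. A single pair also cannot tell whether the step would hold with a different group on the ring nitrogen.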